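The compounds below may be only part of what the source reports. "The series", "measured", "known", "first", "only" and "open" are said of these compounds alone.

In a functional assay on the whole organism (strain Hartley) for inhibition, with Cavia porcellus as the target, with stated times of 15 min and 2 min (on this read-out lower numbers stand for an effect already at smaller amounts and higher numbers for an effect only at larger amounts of compound), compound 1 `CCCCC1([C@@H](O)/C=C/C2CCC(=O)[C@@H]2CCCCCCC(=O)O)CCC1` gives 0.0139 mg/kg. Compound 2 `CCCCC1([C@@H](O)/C=C/C2CCC(=O)[C@@H]2CCCCCCC(=O)OCC)CCC1`, which carries an ethyl group in place of the acid hydrogen, gives 0.032 mg/kg, the higher of the two numbers. The measured change is a 2.3-fold higher number from compound 1 to compound 2 (0.36 log units; beyond the scatter). Compound 3 `CCCCC1([C@H](O)/C=C/C2CCC(=O)[C@@H]2CCCCCCC(=O)OCC)CCC1` has the same atoms and bonds as compound 2, and the two differ only in spatial arrangement: the two compounds have the same atoms and bonds; at least one stereo element is drawn with a configuration in one of them and without one in the other: 1 of 4 stereo elements differ; a stereocentre at a saturated chain carbon is drawn S in compound 2 and R in compound 3. Among the compounds with values here, the one measured step concerns the ethyl group and not this stereocentre, so it gives no direct guide to the size of the new change. Within the data shown here, with no measured pair to go on, a move towards a higher number is expected only tentatively, and a change within the scatter remains possible. The expected move is a 3.1-fold higher number from compound 2 to compound 3 (0.49 log units; beyond the scatter). Compound 3 is estimated at 0.1 mg/kg, with an expected range from 0.012 mg/kg to 0.8 mg/kg.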

Compound 3, dose for half-maximal effect: 0.0151 mg/kg
The estimate for compound 3 lay 6.6-fold (0.82 log units) above the measured number; the measured number falls inside the stated range.
By their numbers in this assay, from the lowest: compounds 1 and 3 (each within the scatter of the next); then compound 2.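

Until now only the ethyl group on the acid had been varied; this result shows that a stereocentre at a saturated chain carbon also counts in this assay: with atoms and bonds unchanged, the data give a 2.1-fold lower number from compound 2 to compound 3 (0.33 log units; beyond the scatter). Drawing this carbon R rather than S thus goes with a modest move towards a smaller dose, so spatial arrangement alone can shift the number beyond the scatter. This step cannot be read as a fully clean swap of one configuration for the other, and the structures themselves give the ground for caution: the fact that one of compounds 2 and 3 is drawn with a defined configuration and the other without, at the place where they differ

The compounds shown leave open whether the same change at this stereocentre would give a similar step in the free carboxylic acid. They also leave open whether it would hold with an amide or a methyl ester in place of the ethyl ester.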